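Swapping a Tertiary Alcohol Tail for a Dimethylamide

This account rests on a few compounds, and the source may have more. Where it says the series, first, only, none or still open, it means among the compounds named here.

In an assay on isolated protein for inhibition of leukotriene B4 receptor 1 (Homo sapiens), tested at 10 uM (a higher number here means more inhibition at the concentration tested (going by the name of the read-out), a lower number less inhibition), compound 2 `C=CCc1cc(C(C)=O)c(O)cc1OCCCCCC(C)(C)O` gives 98%, the highest of the two numbers shown, while compound 1 `C=CCc1cc(C(C)=O)c(O)cc1OCCCC` gives 32%. Compound 3 `C=CCc1cc(C(C)=O)c(O)cc1OCCCCCC(=O)N(C)C` differs from compound 2 by dimethylcarbamoyl in place of 1-hydroxy-1-methylethyl on a saturated chain carbon, five bonds along the chain from an oxygen on an aromatic ring. Within the data shown here, no measured step addresses this change directly. Among the measured compounds shown here, the only step, a number 66 percentage points higher from compound 1 to compound 2 (beyond the scatter), shows that adding the alcohol-bearing tail raised inhibition strongly. Compound 3 keeps a chain of similar length but gives up the hydrogen-bond donor. A modest fall is therefore expected for compound 3, a number 13 percentage points lower from compound 2 to compound 3 (beyond the scatter). Compound 3 is estimated at 85%, with a range from 55% to 99%.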

Compound 3, a percentage reported as inhibition, at one concentration (the size of the read-out at that concentration, not a potency): 92%
Beside the measured number, compound 3's estimate is 7 percentage points below it; the measured number falls inside the stated range.
By their numbers in this assay, from the lowest: compound 1; then compounds 3 and 2 (each within the scatter of the next).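

In this assay, the step with dimethylcarbamoyl in place of 1-hydroxy-1-methylethyl is a number 6 percentage points lower from compound 2 to compound 3 (within the scatter), so a group with 0 hydrogen-bond donors serves here about as well as one with 1. The large rise over the tail of compound 1 therefore does not depend on the hydroxyl group, as the amide tail also gives a number 60 percentage points higher from compound 1 to compound 3 (beyond the scatter). Nothing measured here gives a reason for this. From the compounds shown here alone, whether a carboxylic acid or an amine at the same chain end would match these tails remains open, as does the effect of a longer chain.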